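A few compounds are considered here, and "the series" means these few. Any claim that something is new, unique, unknown or untested is made for them only; others in the source may bear on it.

Measured compounds in a functional assay on MC-38 cells (Mus musculus) for antiproliferative activity, read by CCK-8 assay, with a stated time of 48 h; on this read-out higher numbers stand for weaker inhibition and lower numbers for stronger inhibition:
- compound 1 `COc1ccc(/C=C\c2cc(OC)c(OC)c(OC)c2)cc1OCc1ccc(CN2CCCC[C@H]2C(=O)O)cc1` gives > 10000 nM, which is a limit of the assay.
- compound 2 `COc1ccc(/C=C\c2cc(OC)c(OC)c(OC)c2)cc1OCc1ccc(CN2CC[C@@H](C(=O)O)C2)cc1` gives 6300 nM.
- compound 3 `COc1ccc(/C=C\c2cc(OC)c(OC)c(OC)c2)cc1OCc1ccc(CN2CCCCC2C(=O)NCCN)cc1` gives > 10000 nM, which is a limit of the assay.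

Compound 3 stands at the top of the numbers shown, at the limit of > 10000 nM in this assay, at which 2 of the 3 values shown sit, so only a limit is known for it. Of the steps that reach compound 3, a step that the two limits leave unreadable from compound 1 to compound 3 and an at least 1.5-fold higher number from compound 2 to compound 3 (0.20 log units; that floor lies within the scatter); neither gives a readable size for the change from the carboxylic acids to the amide.

Compound 4 `COc1ccc(/C=C\c2cc(OC)c(OC)c(OC)c2)cc1OCc1ccc(CNCCN(C)C)cc1` differs from compound 3 by (2-(dimethylamino)ethyl)amino in place of 2-((2-aminoethyl)carbamoyl)piperidin-1-yl on a saturated chain carbon bound to an aromatic carbon. Among the measured compounds shown here, no measured step covers this change: the only readable step, an at least 1.5-fold lower number from compound 1 to compound 2 (0.20 log units; that floor lies within the scatter), concerns a different part of the molecule and lies within the scatter. With compound 3 at a limit, the expectation is that compound 4 remains weak in this assay, with a step of an at least 1.1-fold lower number from compound 3 to compound 4 (0.04 log units; that floor lies within the scatter) that is not expected to be readable against the scatter. Compound 4 is estimated at 9000 nM, with a range from 3000 nM to 30000 nM, and a fair chance that only a limit is reported.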

Compound 4, half-maximal inhibitory concentration: 1400 nM
Beside the measured number, compound 4's estimate is 6.4-fold (0.81 log units) above it; measured number below the stated range.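

In this assay, among the compounds shown here, the place on a saturated chain carbon bound to an aromatic carbon now gives steps beyond the scatter, whereas the earlier steps there were within the scatter or unreadable: (2-(dimethylamino)ethyl)amino in place of 2-((2-aminoethyl)carbamoyl)piperidin-1-yl gives an at least 7.1-fold lower number from compound 3 to compound 4 (0.85 log units; beyond the scatter), and in place of 3-carboxypyrrolidin-1-yl it gives a 4.5-fold lower number from compound 2 to compound 4 (0.65 log units; beyond the scatter). In place of 2-carboxypiperidin-1-yl, the same group gives an at least 7.1-fold lower number from compound 1 to compound 4 (0.85 log units; beyond the scatter). The steps from compound 1 and compound 3 are floors only, because both of those compounds sit at a limit: the limit of > 10000 nM in this assay, at which 2 of the 4 values shown sit.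

The change to compound 4 removes the ring and the carbonyl together, so the compounds shown do not separate their contributions. Also open, from the compounds shown here alone, is how a primary amine in place of the dimethylamino end, or a longer chain in place of the ethyl chain, would read in this assay.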